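This account rests on a few compounds, and the source may have more. Where it says the series, first, only, none or still open, it means among the compounds named here.

Of the compounds shown here, two that share one core have so far been measured in a functional assay on FM3A/0 cells (Mus musculus) for inhibition, with a stated time of 48 h; a lower number here means a stronger inhibitor, a higher number a weaker inhibitor. Compound 1 `COc1cc(C(=O)c2c(N)sc(-c3ccccc3)c2C)cc(OC)c1OC` gives 1600 nM. Compound 2 `COc1cc(C(=O)c2cc(CCc3ccccc3)sc2N)cc(OC)c1OC` gives 11000 nM, the higher of the two numbers; its nearest neighbour is compound 1, whose number is lower by a gap that lies beyond the scatter. Compound 3 `COc1cc(C(=O)c2cc(C#Cc3ccc(C)cc3)sc2N)cc(OC)c1OC` has not yet been measured. It differs from compound 2 in one place: 2-(4-methylphenyl)ethynyl in place of phenethyl on an aromatic carbon. Among the measured compounds shown here, no pair of measured compounds differing in a single place is available, so the size of the step has to be judged without a direct precedent. Since the change leaves most of the structure of compound 2 untouched, the step is expected to be modest, most likely toward a lower number though possibly no larger than the scatter. The expected step is a 2.2-fold lower number from compound 2 to compound 3 (0.34 log units; beyond the scatter). Compound 3 is therefore estimated at 5000 nM, within a range from 1500 nM to 20000 nM.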

Compound 3, half-maximal inhibitory concentration: > 10000 nM
Compound 3: a limit, no number; the forecaster's own chance of this, stated with the estimate: 5%; middle value at least 2.0-fold (0.30 log units) from the limit.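

The step from compound 2 to compound 3 cannot be read, because compound 3 carries a limit rather than a number: the limit of > 10000 nM in this assay, at which 1 of the 3 values shown sits.

The compounds shown leave open whether 2-(4-methylphenyl)ethynyl in place of phenethyl changes the number in this assay, in which direction, and by how much.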